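The source may report more compounds than this note shows. Statements on the series, on what has been measured and on what is new or still open speak of the compounds shown alone.

Compound 1 `Cc1cnc(Nc2ccc(C(=O)Nc3c(C)cccc3C)cc2)nc1-c1ccccc1OC(F)(F)F`: > 500 nM
Compound 2 `Cc1cnc(Nc2ccc(C(=O)Nc3c(C)cccc3C)cc2)nc1-c1ccc(OC(F)(F)F)c(F)c1`: 159 nM
Compound 3 `Cc1ccc(-c2nc(Nc3ccc(C(=O)Nc4c(C)cccc4C)cc3)ncc2C)cc1`: > 500 nM

In an assay on NIH3T3 cells for inhibition of Sonic hedgehog protein (Mus musculus), read by a luciferase reporter, with a stated time of 48 h (a higher number here means a weaker inhibitor, a lower number a stronger inhibitor), compound 1 gives > 500 nM, which is a limit of the assay and not a number. Compound 3 likewise gives only > 500 nM, again a limit. Going by the values given here, compound 2 is the one compound with a measured number, 159 nM. Compound 1 therefore stands at the limit of > 500 nM in this assay, at which 2 of the 3 values shown sit, with compound 3 beside it and only compound 2 showing a measurable, stronger inhibition.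

Compound 4 `Cc1cnc(Nc2ccc(C(=O)Nc3c(C)cccc3C)cc2)nc1-c1cnn(C)c1` differs from compound 1 in one place: 1-methyl-1H-pyrazol-4-yl in place of 2-(trifluoromethoxy)phenyl on an aromatic carbon. The measured steps at this same position are an at least 3.1-fold lower number from compound 1 to compound 2 (0.49 log units; beyond the scatter) and an at least 3.1-fold higher number from compound 2 to compound 3 (0.49 log units; beyond the scatter), while a step that the two limits leave unreadable from compound 1 to compound 3. None of these brings in a five-membered ring with two hetero atoms, so they only show the range that substitution at this position has spanned so far, from a limit to a modest measured number. For compound 4 the expected step from compound 1 is an at least 1.2-fold lower number from compound 1 to compound 4 (0.09 log units; that floor lies within the scatter). The value of compound 4 in this assay is estimated at 400 nM, between 120 nM and 1500 nM, with a fair chance that the assay again reports only a limit.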

Compound 4, half-maximal inhibitory concentration: 10.6 nM
Estimate against measurement, compound 4: 38-fold (1.58 log units) above; measured number outside the range, below it.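

Going by these compounds alone, compounds 1, 2 and 3 all carry a six-membered aromatic ring of carbon only at this position, and in this assay the five-membered aromatic ring with 2 hetero atoms goes well past the one measured number among them, with a 15-fold lower number from compound 2 to compound 4 (1.18 log units; beyond the scatter). The other two steps are an at least 47-fold lower number from compound 1 to compound 4 (1.67 log units; beyond the scatter) and an at least 47-fold lower number from compound 3 to compound 4 (1.67 log units; beyond the scatter), and these are only floors, as each begins at a limit of the assay: the limit of > 500 nM in this assay, at which 2 of the 4 values shown sit. A phenyl ring is therefore not needed at this position for inhibition, and 1-methyl-1H-pyrazol-4-yl, with fewer heavy atoms than the 2-(trifluoromethoxy)phenyl it replaces, sets compound 4 clearly apart from the other three compounds.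

The change alters ring size, hetero atoms and group size all at once, and the compounds shown do not separate these, so what drives the step remains open. Also open, as far as these compounds go, is whether the methyl group on the pyrazole matters, and whether the value would hold with a hydrogen or a longer chain such as ethyl in its place, or with a pyridine ring in place of the pyrazole.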